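Phenyl for benzyl on the shared core: acid dissociation expectation

The source may hold more compounds than are shown below. What is called first, only, known or untested is meant among the compounds shown, and "the series" means these compounds.

Measured so far:
compound 1, `COc1cccc(CNCCCNc2ccnc3cc(-c4ccc(C(F)(F)F)cc4)ccc23)c1O`, 9.47
compound 2, `COc1ccc(F)cc1CNCCCNc1ccnc2cc(CCc3ccccc3)ccc12`, 9.47

In a physicochemical assay for acid dissociation, compound 2 gives 9.47, level with compound 1 at the digits shown; the two values lie within the scatter of each other, so no order between them can be read. Compound 1 and compound 2 differ at more than one place, yet their readings in this assay are the same.

Compound 3, `COc1ccc(F)cc1CNCCCNc1ccnc2cc(Cc3ccccc3)ccc12`, has not yet been measured in this assay. It differs from compound 2 in one place: phenyl in place of benzyl on a saturated chain carbon bound to an aromatic carbon. Among the compounds with values here, no pair of measured compounds shows this change, so its effect must be judged from compounds 1 and 2 alone, which stay level across a larger difference.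

Compound 3 is expected to read 9.47 in this assay, with a range from 9.2 to 9.75. The step of no change at the digits printed from compound 2 to compound 3 (within the scatter) is expected to be none beyond the scatter.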

Compound 3, acid dissociation constant: 9.47
The estimate for compound 3 equals the measured number at the digits printed; the range from low to high includes it.
By their numbers in this assay, from the lowest: compounds 1, 2 and 3 (each within the scatter of the next).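

In this assay, phenyl in place of benzyl on a saturated chain carbon bound to an aromatic carbon, which reads phenethyl to benzyl when cut one bond further out, gives no change at the digits printed from compound 2 to compound 3 (within the scatter). The earlier compounds shown here differed in more than one place, whereas this pair isolates a single change at this position and shows that, on this shared core, it leaves the reading within the scatter. No available evidence bears on the reason for this result.

The compounds shown leave open whether a longer chain at this position, or an amine or ether oxygen in place of the saturated chain carbon, would also stay within the scatter. They also leave open whether phenyl in place of benzyl would give the same reading on another core.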